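A few compounds are considered here, and "the series" means these few. Any claim that something is new, unique, unknown or untested is made for them only; others in the source may bear on it.

In a functional assay on HeLa cells (Homo sapiens) for cytotoxicity, read by MTT assay, with a stated time of 24 h (a higher number here means a weaker inhibitor, a lower number a stronger inhibitor), compound 1 `CN1C/C(=C\c2ccc(F)cc2)C(=O)/C(=C/c2cccc([N+](=O)[O-])c2)C1` gives 6250 nM. For the measured compounds named here, only one other measured compound stands beside it: compound 2 `CN1C/C(=C\c2cccc(Br)c2)C(=O)/C(=C/c2cccc([N+](=O)[O-])c2)C1` gives 11100 nM, and these two values lie within the scatter of each other. Compound 3 `CN1C/C(=C\c2ccc(C(F)(F)F)cc2)C(=O)/C(=C/c2cccc([N+](=O)[O-])c2)C1` shares the core of compound 1 and has not yet been measured. It carries trifluoromethyl in place of fluoro on an aromatic carbon. Going by the values given here, one measured step bears on this change, a 1.8-fold higher number from compound 1 to compound 2 (0.25 log units; within the scatter). That step also removes the fluoro group, but it brings in a different substituent, so it is only indirect evidence. On this slender basis, no step beyond the scatter is expected in this assay, and neither direction is favoured. The step expected is a 1.0-fold lower number from compound 1 to compound 3 (0.02 log units; within the scatter). For compound 3 the estimated value is 6000 nM, with an expected range from 2500 nM to 14000 nM.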

Compound 3, half-maximal inhibitory concentration: 3560 nM
Estimate against measurement, compound 3: 1.7-fold (0.23 log units) above; low and high end bracket the measured number.
By their numbers in this assay, from the lowest: compounds 3, 1 and 2 (each within the scatter of the next, the first and the last beyond it).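

In this assay, trifluoromethyl in place of fluoro gives a 1.8-fold lower number from compound 1 to compound 3 (0.24 log units; within the scatter) and so stays within the scatter, even though the entering group has more heavy atoms than the one it replaces. Unlike the earlier step to compound 2, which put a different halogen on a different ring carbon, this step keeps the substituent para to a large group, so only the identity of the group changes. No available evidence accounts for this result.

The compounds shown leave open whether an amine, a carboxylic acid or a methoxy group on this same aromatic carbon would also stay within the scatter of compound 1. They also leave open how trifluoromethyl would read on another carbon of this aromatic ring.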